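Chalcone series: aryl ring swap on compound 2

The compounds below may be only part of what the source reports. "The series", "measured", "known", "first", "only" and "open" are said of these compounds alone.

Measured so far:
- Compound 1, `COc1cc(O)c(C(=O)/C=C/c2ccc(F)cc2)c(OC)c1`: > 20000 nM
- Compound 2, `COc1cc(OC)c(C(=O)/C=C/c2ccc(Cl)cc2)c(OC)c1`: 8200 nM
- Compound 3, `COc1cccc(/C=C/C(=O)c2c(O)cc(OC)cc2OC)c1`: 13200 nM

In a functional assay on MDA-MB-231 cells (Homo sapiens) for cytotoxicity, with a stated time of 48 h (a higher number here means a weaker inhibitor, a lower number a stronger inhibitor), compound 2 gives 8200 nM, the lowest of the two numbers reported; the nearest is compound 3 with 13200 nM, which lies within the scatter, so no order between compound 2 and compound 3 can be claimed. Compound 1 returns only a limit, (the limit of > 20000 nM in this assay, at which 1 of the 3 values shown sits), and not a number.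

The step to be followed goes from compound 2 to compound 4, `COc1cc(OC)c(C(=O)/C=C/c2ccccc2OC)c(OC)c1`. The change is 2-methoxyphenyl in place of 4-chlorophenyl on a double-bonded chain carbon bound to a double-bonded chain carbon. Among the measured compounds shown here, no two measured compounds differ in one place only, so there is no measured step to lean on, and the three measured compounds differ both in the ring bound to the double-bonded chain carbon and in the shared core.

Across the measured set the numbers span only the scatter plus one limit, so for the step in this assay a change of no more than the scatter in either direction is expected, with a weak-inhibitor outcome at the limit not excluded. Compound 4 is estimated at 12000 nM, with a range from 4000 nM to 30000 nM. The step from compound 2 to compound 4 is expected to be a 1.5-fold higher number from compound 2 to compound 4 (0.17 log units; within the scatter).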

Compound 4, half-maximal inhibitory concentration: 13000 nM
Estimate against measurement, compound 4: 1.1-fold (0.03 log units) below, and the stated range covers the measured number.
By their numbers in this assay, from the lowest: compounds 2, 4 and 3 (each within the scatter of the next). At a limit, above all of these: compound 1.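

In this assay, among the compounds shown here, the only step that changes one place alone, 2-methoxyphenyl in place of 4-chlorophenyl on a double-bonded chain carbon bound to a double-bonded chain carbon, reads as a 1.6-fold higher number from compound 2 to compound 4 (0.20 log units; within the scatter) and so does not tell the two rings apart. The earlier compounds shown here could not show this, since none of their differences was read as a step; here the shared core is held fixed, and the exchange of a chlorine for a methoxy group carrying a hydrogen-bond acceptor leaves the number within the scatter. No measured property of either group bears on this result, so no cause can be given for it.

Still open, from the compounds shown here alone, is whether any group at this place can move the number beyond the scatter, for instance a phenyl ring carrying an amine or a carboxylic acid, or a longer chain in place of the ring. Compound 1 gives only > 20000 nM as a limit and not a number, so it offers no value to set against this step.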